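This account rests on a few compounds, and the source may have more. Where it says the series, first, only, none or still open, it means among the compounds named here.

Of the compounds shown here, three built on one shared core have been measured in a functional assay on MGC-803 cells (Homo sapiens) for cytotoxicity, read by MTT assay, with a stated time of 72 h; a higher number here means a weaker inhibitor, a lower number a stronger inhibitor. Compound 1 `Cc1ccccc1Nc1nc(SCc2ccc(C(F)(F)F)cc2)nc2ccccc12` gives 24400 nM. Compound 2 `FC(F)(F)c1ccc(CSc2nc(Nc3cccc(Cl)c3)c3ccccc3n2)cc1` gives 14600 nM, and compound 3 `Fc1ccc(Nc2nc(SCc3ccc(C(F)(F)F)cc3)nc3ccccc23)cc1` gives 9620 nM. The step of a 1.7-fold lower number from compound 1 to compound 2 (0.22 log units; within the scatter) and the step of a 1.5-fold lower number from compound 2 to compound 3 (0.18 log units; within the scatter) are both small, and only a 2.5-fold lower number from compound 1 to compound 3 (0.40 log units; beyond the scatter) reaches beyond the scatter. Compound 3 thus holds the lowest number of the three, but its separation from compound 2 is within the scatter, so no order between those two can be claimed.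

Compound 4 `Fc1ccc(Nc2nc(SCc3ccc(C(F)(F)F)cc3)nc3ccccc23)cc1Cl` has not yet been measured in this assay. It differs from compound 3 by chloro in place of hydrogen on an aromatic carbon. For the measured compounds named here, none of the measured steps bears on this directly: each of them swaps one whole aryl group on the nitrogen for another rather than adding a chloro to a ring that already carries fluoro, and across those swaps the numbers move only modestly. A single chloro entering is a smaller alteration than any of those swaps, so a step no larger than the scatter is expected in this assay, with no firm direction. On that basis compound 4 is estimated at 7500 nM, with a range of 3000 nM to 19000 nM, which amounts to an expected step of a 1.3-fold lower number from compound 3 to compound 4 (0.11 log units; within the scatter).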

Compound 4, half-maximal inhibitory concentration: > 50000 nM
Compound 4 ended at the assay's limit (the forecaster's own chance of this, stated with the estimate: 5%); at least 6.6-fold (0.82 log units) between middle value and limit.
By their numbers in this assay, from the lowest: compounds 3, 2 and 1 (each within the scatter of the next, the first and the last beyond it). At a limit, above all of these: compound 4.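

In this assay compound 4 gives > 50000 nM, which is a limit of the assay and not a number: the limit of > 50000 nM in this assay, at which 1 of the 4 values shown sits. Chloro entering ortho to a fluoro group gives an at least 5.1-fold higher number from compound 3 to compound 4 (0.71 log units; beyond the scatter), and fluoro entering the 3-chlorophenyl group gives an at least 3.4-fold higher number from compound 2 to compound 4 (0.53 log units; beyond the scatter), so neither halogen alone on this ring reaches the limit, while the two together in the 3-chloro-4-fluorophenyl group do. Against the 2-methylphenyl group the change reads an at least 2.0-fold higher number from compound 1 to compound 4 (0.31 log units; beyond the scatter), and the addition of one chloro to the 4-fluorophenyl group thus moves the number further than the largest swap of whole aryl groups seen earlier, a 2.5-fold lower number from compound 1 to compound 3 (0.40 log units; beyond the scatter), which shows a sensitivity on this ring that those swaps did not reveal.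

The compounds shown leave open whether this shift belongs to chloro as such or would follow any group entering ortho to a fluoro group, such as a methyl, a methoxy or an amine. Also open, from the compounds shown here alone, is whether the 3-chloro-4-fluorophenyl group would behave the same way with the trifluoromethyl group replaced by a nitrile or a carboxylic acid.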